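The source may report more compounds than this note shows. Statements on the series, on what has been measured and on what is new or still open speak of the compounds shown alone.

The three compounds share one core, seen in compound 1 `CCCCCC(=O)Nc1ncc(C(Oc2ccc3cc(Br)ccc3c2)c2ccc(Cl)cc2)s1`, compound 2 `CC(C)(C)C(=O)Nc1ncc(C(Oc2ccc3cc(Br)ccc3c2)c2ccc(Cl)cc2)s1` and compound 3 `CCN(CC)C(=O)Nc1ncc(C(Oc2ccc3cc(Br)ccc3c2)c2ccc(Cl)cc2)s1`, and differ only in the group joined to the amide carbonyl. In an ADME assay on HepG2 2.2.15 cells (Homo sapiens) for cytotoxicity (on this read-out higher numbers stand for lower toxicity in this test and lower numbers for higher toxicity in this test), compound 1 gives > 50000 nM, which is a limit of the assay and not a number. In this assay compound 2 is reported as "not toxic" (no number reported), so no single number stands for it. Compound 2 is therefore placed only by the limit of > 50000 nM in this assay, at which 1 of the 2 values shown sits, the limit at which one of the two recorded values sits. Among the measured compounds shown here, no step between two measured compounds is recorded, so the size of any change can only be expected, not read off. Compound 3 carries diethylamino in place of tert-butyl on a carbonyl carbon. With both recorded values sitting at or beyond that limit, the step from compound 2 to compound 3 in this assay is expected to be none beyond the scatter, in no particular direction. Compound 3 is accordingly expected to give about 50000 nM in this assay, within a range of 20000 nM to 100000 nM, most likely reported once more as a limit rather than as a number.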

Compound 3, half-maximal cytotoxic concentration: "not toxic" (no number reported)
The entry for compound 3 holds no number; the estimate stays without a comparison.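

In this assay, among the compounds shown here, compound 3 is recorded as "not toxic" (no number reported), as compound 2 is, so no step from compound 2 to compound 3 can be read. The compounds shown leave open whether exchanging tert-butyl for diethylamino alters this read-out at all, and how far any of them lies from the only figure recorded: the limit of > 50000 nM in this assay, at which 1 of the 3 values shown sits.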